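Series notes: replacing the 1H-pyrazol-4-yl group

This account rests on a few compounds, and the source may have more. Where it says the series, first, only, none or still open, it means among the compounds named here.

Of the compounds shown here, three have numbers so far. In a functional assay on MKN-45 cells (Homo sapiens) for antiproliferative activity, read by CellTiter-Glo, with a stated time of 3 days (a lower number here means a stronger inhibitor, a higher number a weaker inhibitor), compound 1 `COc1ccc(Cl)c([C@@H](C)Oc2c(N)ncc3c(-c4cnn(C5CCNCC5)c4)coc23)c1Cl` gives 1600 nM. Compound 2 `CC(=O)N1CCC(n2cc(-c3coc4c(O[C@H](C)c5c(Cl)ccc(F)c5Cl)c(N)ncc34)cn2)CC1` gives 670 nM. Compound 3 `C[C@@H](Oc1c(N)ncc2c(-c3cn[nH]c3)coc12)c1c(Cl)ccc(F)c1Cl` gives 3300 nM, the highest of the three numbers, with compound 1 the nearest and compound 2 the furthest.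

Compound 4 `CC(=O)N1CC=C(c2coc3c(O[C@H](C)c4c(Cl)ccc(F)c4Cl)c(N)ncc23)CC1` has no number yet. The change from compound 3 to compound 4 is a group of 9 heavy atoms (7 carbon, 1 nitrogen, 1 oxygen; one six-membered non-aromatic ring with 1 hetero atom) in place of a group of 5 heavy atoms (3 carbon, 2 nitrogen; one five-membered aromatic ring with 2 hetero atoms), on an aromatic carbon, two ring bonds from the ring oxygen.

Among the measured compounds shown here, one measured step bears on this change: a 4.9-fold higher number from compound 2 to compound 3 (0.69 log units; beyond the scatter), modest in size, with hydrogen in place of 1-acetylpiperidin-4-yl on an aromatic nitrogen. Compound 4 shares with compound 2 a six-membered non-aromatic ring with 1 hetero atom, but it has no 1H-pyrazol-4-yl group. For the measured compounds named here, that step is therefore only a partial guide, and no measured compound carries the entering group. A move from compound 3 part of the way towards compound 2 in this assay is expected, so the number should fall modestly, though the uncertainty is wide. The expected change is a 2.2-fold lower number from compound 3 to compound 4 (0.34 log units; beyond the scatter). For compound 4 the estimate is 1500 nM, with an expected range of 500 nM to 4500 nM.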

Compound 4, half-maximal inhibitory concentration: 330 nM
Beside the measured number, compound 4's estimate is 4.5-fold (0.66 log units) above it; measured number outside the range, below it.
By their numbers in this assay, from the lowest: compound 4; then compound 2; then compound 1; then compound 3.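

In this assay, the step of a 10-fold lower number from compound 3 to compound 4 (1.00 log units; beyond the scatter) shows that this position, an aromatic carbon two ring bonds from the ring oxygen, does not depend on a 1H-pyrazol-4-yl group: every earlier compound carried one, whereas compound 4 has a six-membered non-aromatic ring with 1 hetero atom attached directly to the shared core. The entering group has 0 hydrogen-bond donors against 1 for the group that leaves, so a donor in this group is not needed for the lower number seen here, and the earlier step of a 4.9-fold higher number from compound 2 to compound 3 (0.69 log units; beyond the scatter) had shown only that a substituent on the pyrazole nitrogen lowers the number relative to the bare ring. No measurement given here explains the size of this step.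

The compounds shown do not separate the contributions of the acetyl group, the ring double bond and the larger ring, so the saturated 1-acetylpiperidin-4-yl group and the same ring carrying a free secondary amine remain the direct tests. From the compounds shown here alone, it also remains open whether a methanesulfonyl group on the ring nitrogen, or a phenyl ring at this position, would give a similar number.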